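Moving a Hydroxyl Around the Phenyl Ring

The compounds below may be only part of what the source reports. "The series", "measured", "known", "first", "only" and "open" are said of these compounds alone.

Compound 3 `Oc1ccc(-c2cc(-c3ccoc3)cc(-c3ccccc3O)n2)cc1` was tested in a functional assay on HeLa cells (Homo sapiens) for cytotoxicity, read by CCK-8 assay; on this read-out higher numbers stand for weaker inhibition and lower numbers for stronger inhibition. In this assay compound 3 gives only a limit of the assay, > 50000 nM. Compound 1 `Oc1ccc(-c2cc(-c3cccs3)cc(-c3ccc(O)cc3)n2)cc1` likewise reaches only a limit, > 50000 nM. For the measured compounds named here, compound 2 `Oc1ccc(-c2cc(-c3ccsc3)cc(-c3ccc(O)cc3)n2)cc1` gives 4370 nM, and the change an at least 11-fold lower number from compound 1 to compound 2 (1.05 log units; beyond the scatter) is the only measured step in the set. That step alters a different ring from the one altered here, so it does not bear directly on the present change. Compound 4 `Oc1ccc(-c2cc(-c3ccoc3)cc(-c3ccc(O)cc3)n2)cc1` differs from compound 3 by 4-hydroxyphenyl in place of 2-hydroxyphenyl on an aromatic carbon. Since two of the three values sit at the limit of > 50000 nM in this assay, at which 2 of the 3 values shown sit, a step starting from a limit cannot be sized from these numbers alone. A moderately lower number is nonetheless estimated for compound 4, an at least 2.5-fold lower number from compound 3 to compound 4 (0.39 log units; beyond the scatter). Compound 4 is therefore expected at 20000 nM, between 4000 nM and 100000 nM.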

Compound 4, half-maximal inhibitory concentration: 3420 nM
Estimate against measurement, compound 4: 5.8-fold (0.77 log units) above; measured number outside the range, below it.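

In this assay, the placing of the hydroxyl on this phenyl group matters: at the place next to the ring nitrogen, 4-hydroxyphenyl in place of 2-hydroxyphenyl gives an at least 14-fold lower number from compound 3 to compound 4 (1.16 log units; beyond the scatter). With both 4-hydroxyphenyl groups kept, furan-3-yl in place of thiophen-3-yl gives a 1.3-fold lower number from compound 2 to compound 4 (0.11 log units; within the scatter), whereas furan-3-yl in place of thiophen-2-yl gives an at least 14-fold lower number from compound 1 to compound 4 (1.16 log units; beyond the scatter). Compound 1 and compound 3 each stand at a limit of the assay, so these two large steps are minimum sizes only: the limit of > 50000 nM in this assay, at which 2 of the 4 values shown sit.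

The compounds shown leave open how a 3-hydroxyphenyl or a 4-aminophenyl group would behave at this same place.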